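This account rests on a few compounds, and the source may have more. Where it says the series, first, only, none or still open, it means among the compounds named here.

Within the data shown here, compound 2 `CC(C)OC(=O)NCCS(=O)(=O)NC(=O)c1ccc(Nc2nc(NC3(c4ccc(Cl)cc4)CC3)nc(OCC(F)(F)F)n2)cc1` gives 73% in an ADME assay on microsomes from liver (Rattus norvegicus) for metabolic stability, with a stated time of 10 min (a higher number here means that more of the compound is left, a lower number that less of the compound is left), the lowest of the two numbers so far; compound 1 `CC(C)(C)OC(=O)NCCS(=O)(=O)NC(=O)c1ccc(Nc2nc(NC3(c4ccc(Cl)cc4)CC3)nc(OCC(F)(F)F)n2)cc1` gives 93%, and the only measured step, a number 20 percentage points lower from compound 1 to compound 2 (beyond the scatter), is modest. Compound 3 `CS(=O)(=O)NC(=O)c1ccc(Nc2nc(NC3(c4ccc(Cl)cc4)CC3)nc(OCC(F)(F)F)n2)cc1` differs from compound 2 by hydrogen in place of ((isopropoxycarbonyl)amino)methyl on a saturated chain carbon bound to a sulfonyl sulfur. Among the measured compounds shown here, no measured step covers this change, since the one step recorded concerns only the alkyl of the carbamate that here leaves altogether, so it gives little guide to direction. In this assay the step is expected to be small, a number 5 percentage points higher from compound 2 to compound 3 (within the scatter), within or near the scatter. Compound 3 is therefore estimated at 78%, in a range from 50% to 95%.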

Compound 3, percent of the compound remaining: 85%
Beside the measured number, compound 3's estimate is 7 percentage points below it, within the range that was stated.
By their numbers in this assay, from the lowest: compound 2; then compounds 3 and 1 (each within the scatter of the next).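

Cutting 2-((isopropoxycarbonyl)amino)ethyl back to methyl gives a number 12 percentage points higher from compound 2 to compound 3 (beyond the scatter) in this assay, so at this position the number does not depend on keeping the carbamate chain. The same cut from the tert-butyl carbamate gives a number 8 percentage points lower from compound 1 to compound 3 (within the scatter), so compound 3 cannot be separated from compound 1 in this assay. No evidence on hand accounts for either step.

Open, on these data alone, is how a free amine or a carboxylic acid at the end of this chain would read in this assay. Also open, as far as these compounds go, is whether an ethyl or longer plain alkyl chain in place of methyl would stay level with compound 3.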